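This account rests on a few compounds, and the source may have more. Where it says the series, first, only, none or still open, it means among the compounds named here.

- compound 1 `c1ccc(/N=N/c2ccc(NC[C@@H]3CCCN4CCCC[C@H]34)c3c2CCCC3)cc1` gives > 100000 nM (a limit)
- compound 2 `Brc1cccc(/N=N/N2CCCCC2)c1` gives > 100000 nM (a limit)
- compound 3 `O=C1CCN(/N=N/c2ccccc2)CC1` gives 90000 nM

All three were tested in an ADME assay on BHK-21 cells (Mesocricetus auratus) for cytotoxicity, read by MTT assay, with a stated time of 96 h (on this read-out higher numbers stand for lower toxicity in this test and lower numbers for higher toxicity in this test), and compound 1 stands at the limit of > 100000 nM in this assay, at which 2 of the 3 values shown sit, so its result is a limit and not a number.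

Compound 4 `FC(F)(F)c1cccc(/N=N/c2ccc(NC[C@@H]3CCCN4CCCC[C@H]34)c3c2CCCC3)c1` has trifluoromethyl in place of hydrogen on an aromatic carbon, meta to a large group, counted as trifluoromethyl in place of hydrogen on an aromatic carbon and otherwise keeps the core of compound 1. Among the compounds with values here, no measured pair shows this change, so the expectation is loose: a modest move towards lower numbers in this assay or none beyond the scatter. The expected change is an at least 1.2-fold lower number from compound 1 to compound 4 (0.09 log units; that floor lies within the scatter) and the assay may again report only a limit. Compound 4 is estimated at 80000 nM, with an expected range from 25000 nM to 100000 nM.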

Compound 4, half-maximal cytotoxic concentration: 14000 nM
Estimate against measurement, compound 4: 5.7-fold (0.76 log units) above; measured number below the stated range.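

In this assay compound 1 gives > 100000 nM, which is a limit of the assay and not a number. Going from phenyl to 3-(trifluoromethyl)phenyl, the first single change shown on the shared core, gives an at least 7.1-fold lower number from compound 1 to compound 4 (0.85 log units; beyond the scatter), so this ring position is not indifferent to what it carries. That step is only a floor because compound 1 sits at a limit: the limit of > 100000 nM in this assay, at which 2 of the 4 values shown sit.

From the compounds shown here alone, whether this shift belongs to trifluoromethyl itself stays open, since a chlorine atom, a methoxy group or an amine at the same place would be needed for comparison. Also open, going by these compounds, is whether trifluoromethyl on another carbon of that ring would give the same result.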